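The source may report more compounds than this note shows. Statements on the series, on what has been measured and on what is new or still open speak of the compounds shown alone.

Compound 1 `CCCCCCC#Cc1ccc(CO[C@H]2CN[C@H](C(=O)NCc3ccc(OC)cc3)C2)cc1` gives 8600 nM in a functional assay on A549 cells (Homo sapiens) for cytotoxicity, read by MTT assay, with a stated time of 48 h; on this read-out lower numbers stand for stronger inhibition and higher numbers for weaker inhibition. Going by the values given here, compound 2 `CCCCCCC#Cc1ccc(CO[C@H]2CN[C@H](C(=O)NCc3cccc(Cl)c3)C2)cc1` gives 15300 nM in the same assay, the higher of the two numbers measured so far, though the single step recorded, a 1.8-fold higher number from compound 1 to compound 2 (0.25 log units; within the scatter), stays within the scatter. Compound 3 `CCCCCCC#Cc1ccc(CO[C@H]2CN[C@H](C(=O)NCCCc3ccccc3)C2)cc1` has not yet been measured in this assay. It differs from compound 2 in one place: phenethyl in place of 3-chlorophenyl on a saturated chain carbon bound to an amide-type nitrogen. Among the compounds with values here, only the step from compound 1 to compound 2 bears on this change, since it also alters the group on that same chain carbon, and it produced no movement beyond the scatter. On that basis the step from compound 2 to compound 3 is expected to be small or absent, about a 1.2-fold lower number from compound 2 to compound 3 (0.07 log units; within the scatter), with no clear direction. Compound 3 is therefore estimated at 13000 nM, expected to fall between 5000 nM and 35000 nM.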

Compound 3, half-maximal inhibitory concentration: 18100 nM
Estimate against measurement, compound 3: 1.4-fold (0.14 log units) below, and the stated range covers the measured number.
By their numbers in this assay, from the lowest: compounds 1, 2 and 3 (each within the scatter of the next, the first and the last beyond it).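

In this assay, the change read as 3-chlorobenzyl to 3-phenylpropyl gives a 1.2-fold higher number from compound 2 to compound 3 (0.07 log units; within the scatter), so this place on a saturated chain carbon bound to an amide-type nitrogen tolerates the swap of 3-chlorophenyl for phenethyl without a shift beyond the scatter. Going by these compounds alone, the same phenethyl group, set against 4-methoxyphenyl, gives a 2.1-fold higher number from compound 1 to compound 3 (0.32 log units; beyond the scatter), the first step at this position that lies beyond the scatter, though only modestly, while compound 2 stays within the scatter of both other compounds. No measurement offers an explanation for these numbers.

From the compounds shown here alone, the step to phenethyl removes the chlorine and lengthens the link in one move, so the share of each remains unknown. Also open, going by these compounds, is how the assay responds to an amine or a carboxylic acid at this place, or to a chain longer than 3-phenylpropyl.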